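A few compounds are considered here, and "the series" means these few. Any claim that something is new, unique, unknown or untested is made for them only; others in the source may bear on it.

Working notes on the series: in a functional assay on J774.A1 cells (Mus musculus) for inhibition, read by Griess assay, with stated times of 1 h and 24 h (a higher number here means a weaker inhibitor, a lower number a stronger inhibitor), compound 1 `CC(C)CCOc1ccccc1C1CC(=O)c2ccccc2O1` gives 42600 nM and compound 2 `C=CCOc1ccccc1C1CC(=O)c2ccccc2O1` gives 38600 nM, so compound 2 stands level with compound 1, the only other measured compound. Compound 3 `CCCCOc1ccccc1C1CC(=O)c2ccccc2O1` differs from compound 2 by propyl in place of vinyl on a saturated chain carbon bound to an oxygen on an aromatic ring. Among the measured compounds shown here, the one measured step at this place, a 1.1-fold lower number from compound 1 to compound 2 (0.04 log units; within the scatter), stays within the scatter, so no step beyond the scatter is expected in this assay. For compound 3 the estimated value is 40000 nM, with an expected range of 22000 nM to 75000 nM. This estimate means an expected 1.0-fold higher number from compound 2 to compound 3 (0.02 log units; within the scatter).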

Compound 3, half-maximal inhibitory concentration: 47700 nM
Compound 3: the middle estimate sits 1.2-fold (0.08 log units) below what was measured; the measured number falls inside the stated range.
By their numbers in this assay, from the lowest: compounds 2, 1 and 3 (each within the scatter of the next).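

In this assay, propyl in place of vinyl on a saturated chain carbon bound to an oxygen on an aromatic ring gives a 1.2-fold higher number from compound 2 to compound 3 (0.09 log units; within the scatter) and so removes the double bond without a step beyond the scatter. Hydrogen in place of methyl on a saturated chain carbon bound to two saturated chain carbons gives a 1.1-fold higher number from compound 1 to compound 3 (0.05 log units; within the scatter) and thus shows that removing the chain branch also stays within the scatter. No supporting measurement bears on this result. On these data alone, whether an amine, a carboxylic acid or a longer chain at this place would give a step beyond the scatter remains open.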